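Replacing the Benzimidazolyl Thioether with a Quinolinyl Ether

A few compounds are considered here, and "the series" means these few. Any claim that something is new, unique, unknown or untested is made for them only; others in the source may bear on it.

Compound 1, `COC(=O)c1cc(OCC(=O)[C@H](CC(=O)O)NC(=O)[C@@H](NC(=O)COc2cccc3ccccc23)C(C)C)no1`, gives 71000 nM in a functional assay on Jurkat cells (Homo sapiens) for inhibition; a lower number here means a stronger inhibitor, a higher number a weaker inhibitor.
Compound 2, `CC(C)[C@H](NC(=O)COc1cccc2ccccc12)C(=O)N[C@@H](CC(=O)O)C(=O)CSc1nc2ccccc2[nH]1`, gives > 200000 nM in this assay; this is a limit of the assay, not a number.

Compound 2 therefore stands at the weak end of the two values shown, sitting at the limit of > 200000 nM in this assay, at which 1 of the 2 values shown sits. For the measured compounds named here, the only measured step, an at least 2.8-fold higher number from compound 1 to compound 2 (0.44 log units; beyond the scatter), is the one that introduced the (1H-benzimidazol-2-yl)sulfanyl group in place of an oxygen-linked ring. Compound 3, `CC(C)[C@H](NC(=O)COc1cccc2ccccc12)C(=O)N[C@@H](CC(=O)O)C(=O)COc1cccc2cccnc12`, undoes exactly that: (quinolin-8-yl)oxy in place of (1H-benzimidazol-2-yl)sulfanyl on a saturated chain carbon bound to a carbonyl carbon. Since an oxygen-linked aromatic ring on that chain carbon, as in compound 1, gave a number rather than a limit, compound 3 is expected to move back in the stronger direction by an at least 2.5-fold lower number from compound 2 to compound 3 (0.39 log units; beyond the scatter). Compound 3 is thus estimated at 80000 nM, within 20000 nM to 300000 nM, though a limit remains possible.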

Compound 3, half-maximal inhibitory concentration: > 200000 nM
Compound 3 gave a limit, no number; the forecaster's own chance of this, stated with the estimate: 35%; middle value at least 2.5-fold (0.39 log units) away from the limit.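

Moving from the benzimidazolyl thioether to an oxygen-linked ring did not by itself bring back a readable value: quinolin-8-yl in place of 5-(methoxycarbonyl)-1,2-oxazol-3-yl on an oxygen on a saturated carbon gives an at least 2.8-fold higher number from compound 1 to compound 3 (0.44 log units; beyond the scatter). So the oxygen link alone does not account for the number seen with compound 1, and of the three compounds, only compound 1 gives a number in this assay, 71000 nM. The step from compound 2 to compound 3 cannot be read, and the two compounds cannot be ranked against each other: the limit of > 200000 nM in this assay, at which 2 of the 3 values shown sit.

The compounds shown do not separate the part played by the 1,2-oxazole ring from that of its methoxycarbonyl group. A carboxylic acid in place of that methyl ester, or an unsubstituted 1,2-oxazol-3-yl ring, would address this question.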